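The source may report more compounds than this note shows. Statements on the series, on what has been measured and on what is new or still open speak of the compounds shown alone.

Compound 1 `CC(C)C(c1ncco1)c1ccc(-c2ccc3cccc(F)c3c2)[nH]c1=O` is the anchor of the series in an ADME assay on microsomes from liver (Rattus norvegicus) for metabolic stability (a higher number here means that the compound lasts longer, a lower number that the compound disappears faster), where compound 1 gives 0.0983 h. Compound 2 `CCn1ncc2c(F)cc(-c3ccc(C(CC)(CC)c4nnc(C)[nH]4)c(=O)[nH]3)cc21` has also been run in this assay , and for compound 2 the read-out is a limit of the assay, > 3 h, not a number. So compound 1 carries the only true number so far, and the other value shown sits at the limit of > 3 h in this assay, at which 1 of the 2 values shown sits. For the measured compounds named here, no two measured compounds differ in a single place, so no measured step in this assay exists against which the change now considered could be calibrated.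

Compound 3 `CC(C)C(c1ncc[nH]1)c1ccc(-c2ccc3cccc(F)c3c2)[nH]c1=O` differs from compound 1 in one place: 1H-imidazol-2-yl in place of 1,3-oxazol-2-yl on a saturated chain carbon bound to an aromatic carbon and a saturated chain carbon. Nothing measured in the series speaks to a ring swap of this kind, so the expectation for this assay is a small step, without a clear direction, and probably not beyond the usual scatter. The step expected is a 1.5-fold higher number from compound 1 to compound 3 (0.18 log units; within the scatter). Compound 3 is estimated at 0.15 h in this assay , with a range from 0.05 h to 0.5 h.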

Compound 3, half-life: < 0.0667 h
Compound 3: no number, only a limit (the forecaster's own chance of this, stated with the estimate: 3%); middle value at least 2.2-fold (0.35 log units) from the limit.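

In this assay compound 3 gives < 0.0667 h, which is a limit of the assay and not a number. For the compounds shown here, the exchange of 1,3-oxazol-2-yl for 1H-imidazol-2-yl, on a saturated chain carbon bound to an aromatic carbon and a saturated chain carbon, supplies the first measured single-place step: an at least 1.4-fold lower number from compound 1 to compound 3 (0.16 log units; that floor lies within the scatter). This step gives the series its first reading at this position, and it shows no longer half-life with this ring swap, though only a floor can be read for the change and that floor does not clear the scatter: the limit of < 0.0667 h in this assay, at which 1 of the 3 values shown sits.

The compounds shown leave open how far compound 3 actually lies from compound 1, and so whether this swap has a real effect on the half-life or one that stays within the scatter. They also leave open what this same saturated chain carbon would give with a different group in place of the 1,3-oxazol-2-yl, such as 1,3-thiazol-2-yl, 1-methyl-1H-imidazol-2-yl or a carboxylic acid.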